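This account rests on a few compounds, and the source may have more. Where it says the series, first, only, none or still open, it means among the compounds named here.

Measured in a functional assay on HeLa cells (Homo sapiens) for inhibition, read by sulforhodamine B assay; on this read-out higher numbers stand for weaker inhibition and lower numbers for stronger inhibition:
- Compound 1 `O=C1C=C(NC2CCCCC2)C(=O)c2c1nc1n2[C@H]2OC[C@@H](O)[C@H]2OC1`: > 16000 nM (a limit)
- Compound 2 `CCc1ccc(NC2=CC(=O)c3nc4n(c3C2=O)[C@H]2OC[C@@H](O)[C@H]2OC4)cc1`: 3990 nM
- Compound 3 `COc1ccccc1NC1=CC(=O)c2nc3n(c2C1=O)[C@H]1OC[C@@H](O)[C@H]1OC3`: 2950 nM

Compound 1 gives only a limit of the assay, > 16000 nM. Going by the values given here, compound 3 cannot be told apart from compound 2, its only neighbour with a true number: a 1.4-fold lower number from compound 2 to compound 3 (0.13 log units; within the scatter). Both lie clear of compound 1, with an at least 4.0-fold lower number from compound 1 to compound 2 (0.60 log units; beyond the scatter) and an at least 5.4-fold lower number from compound 1 to compound 3 (0.73 log units; beyond the scatter).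

Compound 4 `CCCN(CCC)C1=CC(=O)c2nc3n(c2C1=O)[C@H]1OC[C@@H](O)[C@H]1OC3` carries dipropylamino in place of (2-methoxyphenyl)amino on a double-bonded ring carbon. The aromatic ring thus leaves, and the closest guide is compound 1, which also has none on its amine nitrogen. Since an at least 5.4-fold lower number from compound 1 to compound 3 (0.73 log units; beyond the scatter), a move to a higher number is expected in this assay, of modest size and beyond the scatter. Compound 1 and compound 4 still differ in their amine groups, so this guide is rough, and a limit alone remains possible. The expected step is a 3.4-fold higher number from compound 3 to compound 4 (0.53 log units; beyond the scatter). For compound 4 the estimated value is 10000 nM, within an expected range of 3500 nM to 28000 nM.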

Compound 4, half-maximal inhibitory concentration: > 16000 nM
Compound 4: no number, only a limit; the forecaster's own chance of this, stated with the estimate: 35%; middle value at least 1.6-fold (0.20 log units) from the limit.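

In this assay the change to dipropylamino gives an at least 5.4-fold higher number from compound 3 to compound 4 (0.73 log units; beyond the scatter), and the same change gives an at least 4.0-fold higher number from compound 2 to compound 4 (0.60 log units; beyond the scatter). Among the compounds shown, the two amines on this double-bonded ring carbon that carry a six-membered aromatic ring give true numbers, whereas cyclohexylamino and now dipropylamino, which have no such ring, give only limits, and no compound shown goes against this. The step between compound 1 and compound 4 cannot be read, and both stand at the same limit: the limit of > 16000 nM in this assay, at which 2 of the 4 values shown sit.

On these data alone, how far compound 1 and compound 4 actually lie beyond that limit remains open. Also open, as far as these compounds go, is whether a benzylamine, with one carbon between the nitrogen and the aromatic ring, or a morpholine would give a true number here.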